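The compounds below may be only part of what the source reports. "The series", "measured", "known", "first", "only" and "open" are said of these compounds alone.

Three compounds that share a core carrying a sulfur-containing bicyclic ring have been tested in a functional assay on U-937 cells (Homo sapiens) for cytotoxicity, read by MTT assay, with a stated time of 48 h; on this read-out lower numbers stand for stronger inhibition and higher numbers for weaker inhibition. Compound 1, with the structure `Clc1cccc2sc(Nc3nc4ccccc4s3)nc12`, gives only a limit of the assay there, > 50000 nM. Compound 2, with the structure `Fc1ccc(NC(=S)Nc2nc3ccc(F)cc3s2)cc1`, is the one that gives a numerical value in this assay, namely 16200 nM. Compound 3, with the structure `S=C(Nc1ccccc1)Nc1nc2c(Cl)cccc2s1`, is again reported only as a limit in this assay, > 50000 nM. Two of the three results thus sit at the same limit (the limit of > 50000 nM in this assay, at which 2 of the 3 values shown sit), and compound 3 stands among them rather than at a measured number.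

Compound 4, with the structure `S=C(Nc1ccccc1)Nc1nc2ccccc2s1`, has not yet been tested. It differs from compound 3 in a single place: hydrogen in place of chloro on an aromatic carbon. Going by the values given here, no measured pair of compounds shows what this particular change does, so the expectation rests on the fact that compound 3 itself gives no number, only > 50000 nM. The step is expected to be small, a number no higher from compound 3 to compound 4 (the limit leaves the size open), and not beyond the usual scatter. Compound 4 is therefore expected to give about 50000 nM in this assay, within a range from 20000 nM to 120000 nM, and it may well come back as a limit once more.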

Compound 4, half-maximal inhibitory concentration: > 50000 nM
Compound 4: only a limit was reported (the forecaster's own chance of this, stated with the estimate: 65%); the middle value sits exactly at the limit.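

Compound 3 and compound 4 are both reported only as limits in this assay, so no step between them can be read, and the results shown now gather at one limit: the limit of > 50000 nM in this assay, at which 3 of the 4 values shown sit.

The compounds shown leave open whether hydrogen in place of chloro on this aromatic carbon changes the read-out at all.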